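The compounds below may be only part of what the source reports. "The series", "measured", "known", "first", "only" and "open" are said of these compounds alone.

Going by the values given here, in a functional assay on MDA-MB-231 cells (Homo sapiens) for antiproliferative activity, read by sulforhodamine B assay, with a stated time of 48 h (on this read-out lower numbers stand for stronger inhibition of growth and higher numbers for weaker inhibition of growth), compound 3 (`CCCCc1cn(CCCN2C(=O)COc3ccccc32)nn1`) gives 3600 nM, the highest of the three numbers so far, against compound 1 (`Cc1ccc(-c2cn(CCCN3C(=O)COc4ccccc43)nn2)cc1`) at 1120 nM and compound 2 (`CCCCCCc1cn(CCCN2C(=O)COc3ccccc32)nn1`) at 1100 nM. Compound 4 (`CCCc1cn(CCCN2C(=O)COc3ccccc32)nn1`) shortens butyl to propyl: hydrogen in place of methyl on a saturated chain carbon, three bonds along the chain from an aromatic carbon. Among the compounds with values here, the closest precedent is the cut from hexyl to butyl, a 3.3-fold higher number from compound 2 to compound 3 (0.51 log units; beyond the scatter). The aryl comparisons, a 1.0-fold lower number from compound 1 to compound 2 (0.01 log units; within the scatter) and a 3.2-fold higher number from compound 1 to compound 3 (0.51 log units; beyond the scatter), bear only indirectly. The present cut is smaller, so a small rise in this assay, within the scatter, is expected: a 1.4-fold higher number from compound 3 to compound 4 (0.14 log units; within the scatter). For compound 4 the estimate is 5000 nM, with an expected range of 2000 nM to 12000 nM.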

Compound 4, concentration for 50% growth inhibition: 1100 nM
The estimate for compound 4 lay 4.5-fold (0.66 log units) above the measured number, outside the stated range (below it).
By their numbers in this assay, from the lowest: compounds 2, 4 and 1 (each within the scatter of the next); then compound 3.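

In this assay, the number at this position does not follow chain length: butyl to propyl reverses the earlier rise (a 3.3-fold lower number from compound 3 to compound 4 (0.51 log units; beyond the scatter)), leaving compound 3 alone apart from the others. Propyl and hexyl stand level (no change at the digits printed from compound 2 to compound 4 (within the scatter)), and propyl also matches 4-methylphenyl (a 1.0-fold lower number from compound 1 to compound 4 (0.01 log units; within the scatter)), so neither chain length nor the aryl group separates these three. Nothing available explains the butyl value.

Still open, going by these compounds, is whether butyl is a lone exception, and whether a pentyl chain, an amine or a carboxylic acid in this place would fall level with propyl and hexyl.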